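Cytotoxicity notes: from compound 3 to compound 4

The source may report more compounds than this note shows. Statements on the series, on what has been measured and on what is new or still open speak of the compounds shown alone.

The three measured compounds share one core and differ only in the aromatic group on one aromatic carbon: compound 3 `CC(C)N(Cc1cccc(OCCCCCC(=O)O)c1)C(=O)c1ccc(-c2ccc3cc[nH]c3c2)cc1` carries a 1H-indol-6-yl, compound 1 `CC(C)N(Cc1cccc(OCCCCCC(=O)O)c1)C(=O)c1ccc(-c2cccc3ccccc23)cc1` a naphthalen-1-yl, and compound 2 `CC(C)COc1cccc(-c2ccc(C(=O)N(Cc3cccc(OCCCCCC(=O)O)c3)C(C)C)cc2)c1` a 3-(isobutoxy)phenyl. In an ADME assay on HepG2 cells (Homo sapiens) for cytotoxicity, read by CellTiter-Glo and resazurin assay, with a stated time of 72 h (a lower number here means that less compound is needed, a higher number that more compound is needed for the effect), compound 3 gives > 26000 nM, which is a limit and not a number. Compound 1 likewise gives > 26000 nM, a limit. Compound 2 gives > 26000 nM, also a limit. The three steps among them are therefore unreadable: a step that the two limits leave unreadable from compound 1 to compound 2, a step that the two limits leave unreadable from compound 1 to compound 3 and a step that the two limits leave unreadable from compound 2 to compound 3. All three values sit at the same place, (the limit of > 26000 nM in this assay, at which 3 of the 3 values shown sit).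

Compound 4 `CC(C)N(Cc1cccc(OCCCCCC(=O)O)c1)C(=O)c1ccc(-c2cccc(Br)c2)cc1` differs from compound 3 as follows: 3-bromophenyl in place of 1H-indol-6-yl on an aromatic carbon. For the measured compounds named here, no measured step bears on this change with a readable size; the steps from compound 1 onward show only that three different aromatic groups on that carbon all left the value at the limit. For compound 4 the expectation is therefore no step beyond the scatter, a step that the limit leaves unreadable from compound 3 to compound 4, and most likely another limit. Compound 4 is estimated at 30000 nM in this assay, with a range from 15000 nM to 80000 nM.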

Compound 4, half-maximal effective concentration: > 26000 nM
Compound 4 ended at the assay's limit (the forecaster's own chance of this, stated with the estimate: 85%); the middle value lies beyond the limit too.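

Compound 4 gives > 26000 nM in this assay, which is a limit and not a number. Its steps to compound 1, compound 2 and compound 3 therefore cannot be read, and all four compounds sit at one place: the limit of > 26000 nM in this assay, at which 4 of the 4 values shown sit. The compounds shown leave open how far beyond this limit each value lies in this assay, and whether any aromatic group on that carbon gives a readable value.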